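A few compounds are considered here, and "the series" means these few. Any claim that something is new, unique, unknown or untested is made for them only; others in the source may bear on it.

Working notes on the series. In a functional assay on A-431 cells (Homo sapiens) for antiproliferative activity, read by sulforhodamine B assay, with a stated time of 72 h (a lower number here means a stronger inhibitor, a higher number a weaker inhibitor), compound 2 `C=C1C[C@](CBr)(c2ccccc2)OC1=O` gives 1330 nM. Among the measured compounds shown here, compound 1 `C=C1CC(CBr)(c2ccccc2)OC1=O` gives 1480 nM, which is within the scatter of compound 2, so the two share the low end of the numbers so far. Compound 3 `C=C1CC(C)(CBr)OC1=O` gives 124000 nM, far higher than either and well beyond the scatter.

The next compound to be read is compound 4 `C=C1C[C@](CCl)(c2ccccc2)OC1=O`, which has not yet been measured. The change is chloro in place of bromo on a saturated chain carbon bound to a saturated ring carbon, or bromomethyl to chloromethyl when cut one bond further out.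

For the measured compounds named here, the only measured step, a 1.1-fold lower number from compound 1 to compound 2 (0.05 log units; within the scatter), goes with the fact that one of compounds 1 and 2 is drawn with a defined configuration and the other without, at the place where they differ and leaves the halogen untouched. It therefore gives no direct measure for this change. Going by the values given here, no compound so far carries any halogen other than bromo, so the expectation in this assay is loose: a modest move toward a higher number, which may not clear the scatter. The expected change is a 1.9-fold higher number from compound 2 to compound 4 (0.27 log units; within the scatter). For compound 4 the estimated value is 2500 nM, with an expected range of 800 nM to 8000 nM.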

Compound 4, half-maximal inhibitory concentration: 30600 nM
Compound 4: middle estimate off by 12-fold (1.09 log units), on the low side; measured number above the stated range.
By their numbers in this assay, from the lowest: compounds 2 and 1 (each within the scatter of the next); then compound 4; then compound 3.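

In this assay the halogen on a saturated chain carbon bound to a saturated ring carbon proves to be a sensitive point: chloro in place of bromo gives a 23-fold higher number from compound 2 to compound 4 (1.36 log units; beyond the scatter) with no other change to the structure. The only earlier step concerned the drawn configuration and stayed within the scatter, so this is the first single change in the compounds shown that moves the number by a large margin, and it separates compound 4 clearly from compound 2. Nothing at hand bears on why exchanging these two halogens has an effect of this size.

The compounds shown leave open how fluoromethyl, iodomethyl or hydroxymethyl would read on the shared core against bromomethyl and chloromethyl, and so whether the numbers follow any order across such groups. Also open is whether the halogen exchange has a similar size with methyl in place of the phenyl group, as the compound 3 pattern is shown only with bromomethyl, and whether the opposite configuration of compound 4 would read the same.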